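The source may hold more compounds than are shown below. What is called first, only, known or untested is meant among the compounds shown, and "the series" means these compounds.

The measured compounds, all read in a functional assay on the whole organism for inhibition, with Rattus norvegicus as the target, read by paw edema, at a dose of 100 mg/kg by the oral route; on this read-out lower numbers stand for less inhibition and higher numbers for more inhibition at the one dose given (going by the name of the read-out):

Compound 1, `COc1cccc(NC(=O)c2c(O)c3cccnc3n(-c3ccccc3)c2=O)c1`, gives 5.7%.
Compound 2, `O=C(Nc1cccc(Cl)c1)c1c(O)c2cccnc2n(-c2ccccc2)c1=O`, gives 7.6%.
Compound 3, `COc1ccc(NC(=O)c2c(O)c3cccnc3n(-c3ccccc3)c2=O)cn1`, gives 13.1%.

Compound 4, `O=C(Nc1ccc(Cl)nc1)c1c(O)c2cccnc2n(-c2ccccc2)c1=O`, has not yet been measured in this assay. It differs from compound 3 in one place: chloro in place of methoxy on an aromatic carbon. The same kind of change separates compound 1 from compound 2: chloro in place of methoxy on an aromatic carbon. That step in this assay was a number 1.9 percentage points higher from compound 1 to compound 2 (within the scatter), within the scatter. The two places are not the same word for word. In compound 1 the exchange is on an aromatic carbon of a six-membered aromatic ring of carbon only, meta to a large group; in compound 3 it is on an aromatic carbon of a six-membered aromatic ring with one nitrogen, next to the ring nitrogen, para to a large group. So the change is of the same kind, not the same. The two cores differ as follows: 6-methoxypyridin-3-yl in place of 3-methoxyphenyl on an amide-type nitrogen, a step of a number 7.4 percentage points higher from compound 1 to compound 3 (within the scatter), within the scatter. Compound 2 to compound 3 also stays within the scatter, at a number 5.5 percentage points higher from compound 2 to compound 3 (within the scatter).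

Among the measured compounds shown here, with only three compounds measured, all within the scatter of one another, no trend can be claimed. Compound 4 is expected to sit close to its starting point because the like step was a number 1.9 percentage points higher from compound 1 to compound 2 (within the scatter), a small one. That starting point is compound 3, which gives 13.1%. The expected step from compound 3 to compound 4 is a number 0.9 percentage points higher from compound 3 to compound 4 (within the scatter). Compound 4 is therefore estimated at 14%, with a range from 3% to 26%.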

Compound 4, a percentage reported as inhibition, in the whole organism at one dose (the size of the read-out at that dose, not a potency): 9.2%
Compound 4: the middle estimate sits 4.8 percentage points above what was measured; the range from low to high includes it.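

In this assay, chloro in place of methoxy on the six-membered aromatic ring with one nitrogen gave a number 3.9 percentage points lower from compound 3 to compound 4 (within the scatter), and this step does not differ from the one seen for the same kind of change on the other core: the same change on two cores in this assay, a number 1.9 percentage points higher (within the scatter) from compound 1 to compound 2 and a number 3.9 percentage points lower (within the scatter) from compound 3 to compound 4, 5.8 percentage points apart, within the scatter of two such steps The remaining steps to compound 4, which exchange the whole group on the amide nitrogen, also stay small, at a number 1.6 percentage points higher from compound 2 to compound 4 (within the scatter) and a number 3.5 percentage points higher from compound 1 to compound 4 (within the scatter). This shows that, at the one oral dose tested, carrying the change from one core to the other gave no difference that can be told from the scatter, but it does not show that the change acts alike on both cores, or that it has any effect on either, and the opposite directions of the two steps carry no meaning.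

The four compounds shown vary only methoxy and chloro on the aromatic ring attached to the amide nitrogen, while the shared core and its phenyl group stay the same. Going by these compounds, whether an amine or a carboxylic acid in place of chloro, or a longer chain on the amide nitrogen, would move the read-out beyond the scatter remains open.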